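Cytotoxicity in monocytic cells along one amidoxime series

A few compounds are considered here, and "the series" means these few. Any claim that something is new, unique, unknown or untested is made for them only; others in the source may bear on it.

Going by the values given here, compound 2 `CC1(Cc2ccccc2)CC(S(=O)(=O)c2ccccc2)=C(c2ccc(/C(N)=N/O)cc2)O1` is the one member of this set with a numerical read-out: in an ADME assay on THP-1 cells (Homo sapiens) for cytotoxicity, read by flow cytometry, with a stated time of 72 h (a higher number here means a weaker inhibitor, a lower number a stronger inhibitor), compound 2 gives 94600 nM. Compound 1 `N/C(=N\O)c1ccc(C(=O)CS(=O)(=O)c2ccc(/C(N)=N/O)cc2)cc1` is reported only as a limit of the assay, > 125000 nM in this assay. So compound 2 stands as the sole number, with the other entry sitting at the limit of > 125000 nM in this assay, at which 1 of the 2 values shown sits, and the two values together say only that both compounds are weak here; no pair of measured compounds differs in a single place, so no measured step is available.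

Compound 3 `CC1(Cc2ccccc2)CC(S(=O)(=O)c2ccc(Nc3ccc(/C(N)=N/O)cc3)cc2)=C(c2ccc(/C(N)=N/O)cc2)O1` is the untested analogue. It differs from compound 2 by a group of 11 heavy atoms (7 carbon, 3 nitrogen, 1 oxygen; one six-membered aromatic ring of carbon only) in place of a hydrogen atom, on an aromatic carbon, para to a large group. Among the compounds with values here, with no measured step to lean on, the expectation is for no change beyond the usual scatter, with a slight lean toward a lower number, as the estimated step of a 1.2-fold lower number from compound 2 to compound 3 (0.07 log units; within the scatter) expresses. In this assay compound 3 is estimated at 80000 nM, within 30000 nM to 150000 nM, and a limit read-out remains quite possible.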

Compound 3, half-maximal inhibitory concentration: 47600 nM
Compound 3: the middle estimate sits 1.7-fold (0.23 log units) above what was measured; the measured number falls inside the stated range.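

In this assay, the series now has its first measured step between compounds that differ in one place: a 2.0-fold lower number from compound 2 to compound 3 (0.30 log units; within the scatter). The aromatic carbon para to a large group therefore carries a group of 11 heavy atoms (7 carbon, 3 nitrogen, 1 oxygen; one six-membered aromatic ring of carbon only) in place of a hydrogen atom with no shift beyond the scatter, so even a substitution of this size does not separate the two compounds in this read-out. Nothing available bears on the reason for this result.

On these data alone, it remains open how an amine, a carboxylic acid or a methoxy group on the same aromatic carbon would read in this assay, and so a single step cannot show whether the size of the entering group matters at this position. Compound 1 remains outside any comparison, since it differs from the other compounds in more than one place and its entry of > 125000 nM is a limit of the assay and not a number.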